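The source may hold more compounds than are shown below. What is called first, only, known or untested is meant among the compounds shown, and "the series" means these compounds.

In a functional assay on KARPAS-422 cells (Homo sapiens) for antiproliferative activity, read by resazurin assay, with a stated time of 72 h (on this read-out higher numbers stand for weaker inhibition and lower numbers for stronger inhibition), three compounds have been measured:
compound 1 `Cc1cc(C)c(CN2CCc3c(Cl)cc([C@H](CO)[C@H]4CCOC4)c(Cl)c3C2=O)c(=O)[nH]1`: 15 nM
compound 2 `Cc1cc(C)c(CN2CCc3c(Cl)cc([C@@H](CO)[C@@H]4CCOC4)c(Cl)c3C2=O)c(=O)[nH]1`: 3950 nM
compound 3 `Cc1cc(C)c(CN2CCc3c(Cl)cc([C@H](C)CO)c(Cl)c3C2=O)c(=O)[nH]1`: 186 nM

Compound 3, at 186 nM, holds the middle place of these three numbers, higher than compound 1 and lower than compound 2. The next compound is compound 4 `Cc1cc(C)c(CN2CCc3c(Cl)cc([C@@H](CO)[C@H]4CCCO4)c(Cl)c3C2=O)c(=O)[nH]1`, and the change is oxolan-2-yl in place of methyl on a saturated chain carbon bound to an aromatic carbon and a saturated chain carbon.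

Among the measured compounds shown here, two measured steps bear on this change, both exchanging oxolan-3-yl for methyl: a 12-fold higher number from compound 1 to compound 3 (1.09 log units; beyond the scatter) and a 21-fold lower number from compound 2 to compound 3 (1.33 log units; beyond the scatter). Both are large, but they run in opposite directions. The configuration alone separates their starting points, as a 260-fold higher number from compound 1 to compound 2 (2.42 log units; beyond the scatter) shows (the fact that compounds 1 and 2 differ only in the configuration as drawn). For the measured compounds named here, no measured compound carries oxolan-2-yl, so no firm direction is expected in this assay, and the central expectation is no step beyond the scatter, with wide uncertainty on both sides.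

For compound 4 the estimated value is 150 nM, with an expected range of 15 nM to 1500 nM. This estimate means an expected 1.2-fold lower number from compound 3 to compound 4 (0.09 log units; within the scatter).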

Compound 4, half-maximal inhibitory concentration: 535 nM
For compound 4 the middle estimate is 3.6-fold (0.55 log units) below the measured one, within the range that was stated.
By their numbers in this assay, from the lowest: compound 1; then compound 3; then compound 4; then compound 2.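

In this assay, a five-membered oxygen ring on this saturated chain carbon does not of itself improve on methyl, since oxolan-2-yl gives a 2.9-fold higher number from compound 3 to compound 4 (0.46 log units; beyond the scatter). Compound 4 also lies apart from both oxolan-3-yl compounds, with a 7.4-fold lower number from compound 2 to compound 4 (0.87 log units; beyond the scatter) and a 36-fold higher number from compound 1 to compound 4 (1.55 log units; beyond the scatter), so the oxolan-2-yl result falls inside the wide span that those two set. No single value can therefore stand for oxolan-3-yl in a comparison with oxolan-2-yl, and the ground for that is: the fact that compounds 1 and 2 differ only in the configuration as drawn

On these data alone, how the other configurations of oxolan-2-yl would read stays open. Also open, as far as these compounds go, is how an open methoxyethyl chain or a six-membered oxan-4-yl ring would compare with methyl on this carbon.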